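Sulfur for Oxygen on a Dichlorophenyl Side Group

The compounds below may be only part of what the source reports. "The series", "measured", "known", "first", "only" and "open" are said of these compounds alone.

Compound 1 `Nc1cc(N)c2nc(-c3ccccc3)c(Oc3ccc(Cl)c(Cl)c3)nc2c1` carries a 3,4-dichlorophenoxy group on the shared core. In a functional assay on OVCAR-5 cells (Homo sapiens) for inhibition, read by sulforhodamine B assay, with a stated time of 48 h (a higher number here means that more compound is tolerated, a lower number that less compound is tolerated), compound 1 gives < 100000 nM, which is a limit of the assay rather than a number. Compound 2 `COc1cc(CNc2nc3cc(N)cc(N)c3nc2-c2ccccc2)cc(OC)c1OC` gives < 50200 nM in this assay, again only a limit. Compound 3 `COc1ccc(CNc2nc3cc(N)cc(N)c3nc2-c2ccccc2)cc1` gives < 100000 nM in this assay, also a limit. Compound 1 therefore sits at the limit of < 100000 nM in this assay, at which 2 of the 3 values shown sit. Compound 2 sits at the limit of < 50200 nM in this assay, at which 1 of the 3 values shown sits. Among the measured compounds shown here, no step between two measured compounds can be drawn from these values, and they offer no direction for the change that leads to compound 4 `Nc1cc(N)c2nc(-c3ccccc3)c(Sc3ccc(Cl)c(Cl)c3)nc2c1`.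

Compound 4 differs from compound 1 by (3,4-dichlorophenyl)sulfanyl in place of 3,4-dichlorophenoxy on an aromatic carbon, in words: (3,4-dichlorophenyl)sulfanyl in place of 3,4-dichlorophenoxy on an aromatic carbon. With every shown value a limit, no change beyond the usual scatter is expected for a step that the limit leaves unreadable from compound 1 to compound 4. Compound 4 is estimated at 60000 nM, within 15000 nM to 150000 nM, and it is expected that the assay will most likely again report a limit rather than a number.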

Compound 4, concentration lethal to 50% of the cells: 91200 nM
For compound 4 the middle estimate is 1.5-fold (0.18 log units) below the measured one; measured number inside the range.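

In this assay compound 1 gives < 100000 nM, which is a limit and not a number. Among the compounds shown here, compound 4 gives 91200 nM, so no step from compound 1 to compound 4 can be read. The compounds shown leave open whether exchanging 3,4-dichlorophenoxy for (3,4-dichlorophenyl)sulfanyl changes the value at all.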